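From compound 2 to compound 3: one group removed

A few compounds are considered here, and "the series" means these few. Any claim that something is new, unique, unknown or untested is made for them only; others in the source may bear on it.

- compound 1 (`CN1CCC(C(=O)N2Cc3c(NC(=O)c4ccc5ccccc5c4)n[nH]c3C2(C)C)CC1`) gives (219000 nM)
- compound 2 (`CN1CCC(C(=O)N2Cc3c(NC(=O)c4ccc(C(F)(F)F)cc4)n[nH]c3C2(C)C)CC1`) gives (191000 nM)
- compound 3 (`CN1CCC(C(=O)N2Cc3c(NC(=O)c4ccccc4)n[nH]c3C2(C)C)CC1`) is not yet measured

In a physicochemical assay for solubility, at pH 7 (a higher number here means a more soluble compound, a lower number a less soluble compound), compound 2 stands within the scatter of compound 1 (a 1.1-fold lower number from compound 1 to compound 2 (0.06 log units; within the scatter)). Compound 3 carries hydrogen in place of trifluoromethyl on an aromatic carbon. Among the compounds with values here, only that one measured step bears on this change, and it replaced a different group, so it is indirect evidence. It lay within the scatter, so no step beyond the scatter is expected in this assay. The expected step is small (a 1.0-fold higher number from compound 2 to compound 3 (0.02 log units; within the scatter)). Compound 3 is estimated at (200000 nM), with an expected range (110000 nM to 350000 nM).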

Compound 3, solubility: > 225000 nM
Compound 3 gave a limit, no number (the forecaster's own chance of this, stated with the estimate: 10%); middle value at least 1.1-fold (0.05 log units) away from the limit.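

In this assay, compound 3 gives no number, only a limit: the limit of > 225000 nM in this assay, at which 1 of the 3 values shown sits.

Taking off the trifluoromethyl gives an at least 1.1-fold higher number from compound 2 to compound 3 (0.07 log units; that floor lies within the scatter), and phenyl in place of naphthalen-2-yl gives an at least 1.0-fold higher number from compound 1 to compound 3 (0.01 log units; that floor lies within the scatter). Neither floor shows a step beyond the scatter, so these three groups on the carbonyl are not told apart here, and the true size of both steps cannot be read.

From the compounds shown here alone, whether an amine or a carboxylic acid on this aromatic carbon would give a step beyond the scatter stays open.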